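The source may report more compounds than this note shows. Statements on the series, on what has been measured and on what is new or still open speak of the compounds shown alone.

Measured so far:
Compound 1, `COc1nc(C2CCCCC2)ccc1[C@@H](c1ccccc1)[C@@](O)(CCN(C)C)c1cccc2ccccc12`, gives 32.3 ug/mL in a toxicity assay on Vero cells (Chlorocebus sabaeus) for cytotoxicity; on this read-out higher numbers stand for lower toxicity in this test and lower numbers for higher toxicity in this test.
Compound 2, `COc1nc(-c2ccc(C(F)(F)F)cc2)ccc1[C@@H](c1ccccc1)[C@@](O)(CCN(C)C)c1cccc2ccccc12`, reaches the limit of > 50 ug/mL in this assay.

Compound 2 thus stands at the upper edge of what the test can report: its value is a limit, not a number, as its entry the limit of > 50 ug/mL in this assay, at which 1 of the 2 values shown sits, shows. Among the compounds with values here, the single measured step, an at least 1.5-fold higher number from compound 1 to compound 2 (0.18 log units; that floor lies within the scatter), points in the same direction but rests on that limit. Compound 3, `COc1nc(-c2ccc(Cl)c(F)c2)ccc1[C@@H](c1ccccc1)[C@@](O)(CCN(C)C)c1cccc2ccccc12`, differs from compound 2 by an exchange of one aromatic group for another: 4-chloro-3-fluorophenyl in place of 4-(trifluoromethyl)phenyl on an aromatic carbon. Within the data shown here, no measured step exchanges one aromatic group for another, so that single step offers only indirect guidance. With no basis for a shift, the expected step is a number no higher from compound 2 to compound 3 (the limit leaves the size open), that is none beyond the scatter. Compound 3 is therefore estimated at 50 ug/mL in this assay, with a range from 25 ug/mL to 100 ug/mL, and a sizeable chance that only a limit is reported again.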

Compound 3, half-maximal cytotoxic concentration: > 50 ug/mL
Compound 3: no number, only a limit; the forecaster's own chance of this, stated with the estimate: 50%; the middle value lies on the limit itself.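

In this assay compound 3, with 4-chloro-3-fluorophenyl at this place, gives > 50 ug/mL, which is a limit and not a number, so a second aromatic group here also ends at a limit. On these data alone, putting this group in place of cyclohexyl gives an at least 1.5-fold higher number from compound 1 to compound 3 (0.18 log units; that floor lies within the scatter), and the true size of the step remains unknown. Whether exchanging 4-(trifluoromethyl)phenyl for 4-chloro-3-fluorophenyl changes anything cannot be read, since both compounds stop at the same limit: the limit of > 50 ug/mL in this assay, at which 2 of the 3 values shown sit.

As far as these compounds go, the true numbers of compound 2 and compound 3 stay open, so the two aromatic groups cannot be ranked against each other. Also open, from the compounds shown here alone, is how a group of a different kind at this place, such as an amine or a carboxylic acid, would read in this assay.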